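Ethyl in Place of tert-Butyl on the Ring Nitrogen

This account rests on a few compounds, and the source may have more. Where it says the series, first, only, none or still open, it means among the compounds named here.

Among the measured compounds shown here, compound 1 `Cn1nc(Cc2cccc3ccccc23)c2ccccc2c1=O` is the only member of this small set with a numerical result: in a functional assay on aorta with Alpha-1D adrenergic receptor (Rattus norvegicus) as the target (on this read-out higher numbers stand for an effect only at larger amounts of compound and lower numbers for an effect already at smaller amounts), compound 1 gives 14000 nM. Compound 2 `CSc1ccc(Cc2nn(C(C)(C)C)c(=O)c3ccccc23)cc1` stands apart. For compound 2 this assay reports only a limit, > 100000 nM, and not a number. That is the limit of > 100000 nM in this assay, at which 1 of the 2 values shown sits, which places compound 2 at the weak edge of what this assay can resolve. Compound 3 `CCn1nc(Cc2ccc(SC)cc2)c2ccccc2c1=O` differs from compound 2 in a single place: ethyl in place of tert-butyl on an aromatic nitrogen. For the measured compounds named here, no measured pair isolates this change, so its size is unknown from the data. Because compound 2 sits at the limit of > 100000 nM in this assay, at which 1 of the 2 values shown sits, any movement toward effect at smaller amounts would appear as a number. The expected step from compound 2 to compound 3 is an at least 2.0-fold lower number from compound 2 to compound 3 (0.30 log units; that floor lies within the scatter). Compound 3 is expected to give about 50000 nM in this assay, within a range from 10000 nM to 200000 nM.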

Compound 3, half-maximal effective concentration: > 100000 nM
Compound 3 was reported as a limit; the forecaster's own chance of this, stated with the estimate: 45%; middle value at least 2.0-fold (0.30 log units) from the limit.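

Compound 2 and compound 3 are both reported only as limits in this assay, so no step between them can be read: the limit of > 100000 nM in this assay, at which 2 of the 3 values shown sit.

The compounds shown leave open whether ethyl in place of tert-butyl on an aromatic nitrogen changes the effect at all, and in which direction.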